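The compounds below may be only part of what the source reports. "The series", "measured", "known", "first", "only" and "open" are said of these compounds alone.

Measured in a functional assay on BV-2 cells (Mus musculus) for inhibition, read by Griess assay, with a stated time of 24 h; a lower number here means a stronger inhibitor, a higher number a weaker inhibitor:
- compound 1 `COc1ccc(Br)cc1-c1cc(CN2CCN(C(=O)OC(C)(C)C)CC2)on1`: > 200000 nM, a limit
- compound 2 `C=CCc1ccc(OC)c(-c2cc(CCC)on2)c1`: > 200000 nM, a limit

Among the measured compounds shown here, compound 1 has no number on this read-out, only a limit, and the series so far stands at the limit of > 200000 nM in this assay, at which 2 of the 2 values shown sit. Next comes compound 3 `C=CCc1ccc(OC)c(-c2cc(CN3CCN(C(=O)OC(C)(C)C)CC3)on2)c1`, which keeps the core of compound 1 with one exchange: allyl in place of bromo on an aromatic carbon, para to a methoxy group (allyl in place of bromo on an aromatic carbon). For the measured compounds named here, no step between measured compounds is available to size this change. Compound 2, which also carries allyl, gives > 200000 nM, and this too is a limit. With only limits in hand, compound 3 is expected to stay weak in this assay, at the limit or close to it, and any number that does appear is expected on the stronger side. The expected size of an at least 1.3-fold lower number from compound 1 to compound 3 (0.12 log units; that floor lies within the scatter) is small and poorly defined. For compound 3 the estimated value is 150000 nM, with an expected range of 30000 nM to 300000 nM.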

Compound 3, half-maximal inhibitory concentration: 76900 nM
For compound 3 the middle estimate is 2.0-fold (0.29 log units) above the measured one, within the range that was stated.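

In this assay, among the compounds shown here, the exchange of bromo for allyl on the aromatic carbon para to a methoxy group gives an at least 2.6-fold lower number from compound 1 to compound 3 (0.41 log units; beyond the scatter), which shows that this position responds to the change and yields the first actual number. Compound 1 gives > 200000 nM, a limit, so the step is a floor and its full size cannot be read. Allyl alone does not bring out a number, as compound 2, which also carries allyl, gives > 200000 nM, also a limit.

Going by these compounds, only compound 3 has a number so far, so no ranking of groups at this position can be read from the values in hand: the limit of > 200000 nM in this assay, at which 2 of the 3 values shown sit. Still open is whether a longer chain, an amine or a carboxylic acid in place of allyl at this position would lower the number further, and whether a hydrogen there would place the unsubstituted parent above or below compound 3.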